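The compounds below may be only part of what the source reports. "The series", "measured", "known", "first", "only" and "open" are said of these compounds alone.

Measured compounds:
- compound 1, `CCCCc1cnc(C(CCC)Cc2ccc(-c3ccccc3C(=O)O)cc2)[nH]1` — 165 nM
- compound 2, `CC(C)(C)Cc1cnc(CCc2ccc(-c3ccccc3C(=O)O)cc2)[nH]1` — 6.3 nM
- compound 3, `O=C(O)c1ccccc1-c1ccc(CCc2ncc(CC3CC3)[nH]2)cc1` — 72 nM

In an in vitro functional assay on cells for agonist activity at Bombesin receptor subtype-3 (Mus musculus), read by luminescence and calcium flux (a higher number here means that more compound is needed for the effect, a lower number that less compound is needed), compound 1 stands with the highest of the three numbers. Its nearest neighbour is compound 3, and the gap between the two lies beyond the scatter; the largest gap is to compound 2. For the measured compounds named here, the one change between measured compounds that can be read as a single step is an 11-fold higher number from compound 2 to compound 3 (1.06 log units; beyond the scatter), a large step, but it concerns a different part of the molecule from the change followed here.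

Compound 4, `CCCCc1cnc(C(CC)Cc2ccc(-c3ccccc3C(=O)O)cc2)[nH]1`, differs from compound 1 by hydrogen in place of methyl on a saturated chain carbon, three bonds along the chain from an aromatic carbon. Going by the values given here, no measured pair shows this change, so nothing in the data tells how the shared core answers to shortening this chain. Among the compounds with values here, the change is small in what it removes, and with no step bearing on it, the expectation is a step of no size beyond the scatter, a 1.1-fold lower number from compound 1 to compound 4 (0.04 log units; within the scatter), with the uncertainty spread to either side. Compound 4 is therefore expected to give about 150 nM in this assay, with a range from 55 nM to 420 nM.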

Compound 4, half-maximal effective concentration: 340 nM
Compound 4: the middle estimate sits 2.3-fold (0.36 log units) below what was measured; the measured number falls inside the stated range.
By their numbers in this assay, from the lowest: compound 2; then compound 3; then compound 1; then compound 4.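

In this assay, for the compounds shown here, the step of a 2.1-fold higher number from compound 1 to compound 4 (0.31 log units; beyond the scatter) gives the first reading of this position, and it is modest but lies beyond the scatter, so the shared core does respond to the change from propyl to ethyl at this chain. The direction is also new information: taking away a methyl, a single carbon with no ring, donor, acceptor or charge involved, moves the number up rather than leaving it in place, whereas the earlier single step between compound 2 and compound 3 spoke only to a different part of the molecule. No measurement shown here accounts for why the shorter chain goes this way.

Going by these compounds, with only propyl and ethyl at this position, two points fix no trend, and it remains open whether the number would keep rising with a methyl there or fall again with a longer chain such as butyl or pentyl. Also open, on these data alone, is how this carbon would answer to a branched chain such as isopropyl, a cyclopropyl ring, or a hydroxyl or an amine on the chain.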